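Ortho-methoxy anilide of a chromone acrylamide series

A few compounds are considered here, and "the series" means these few. Any claim that something is new, unique, unknown or untested is made for them only; others in the source may bear on it.

Measured compounds:
compound 1 `COc1ccc2c(=O)c(/C=C/C(=O)Nc3ccccc3)coc2c1` — 523000 nM
compound 2 `COc1ccc2c(=O)c(/C=C/C(=O)NCc3cccc(F)c3)coc2c1` — 475000 nM
compound 3 `COc1ccc(NC(=O)/C=C/c2coc3cc(OC)ccc3c2=O)cc1` — 718000 nM

Three amides sharing the core of compound 1 have been tested in an ADME assay on HepG2 2.2.15 cells (Homo sapiens) for cytotoxicity, read by MTT assay, with stated times of 48 h and 9 days; on this read-out lower numbers stand for higher toxicity in this test and higher numbers for lower toxicity in this test. Compound 1 gives 523000 nM in this assay; its number sits between those of compound 2 and compound 3, and both steps, a 1.1-fold lower number from compound 1 to compound 2 (0.04 log units; within the scatter) and a 1.4-fold higher number from compound 1 to compound 3 (0.14 log units; within the scatter), fall within the scatter, as does a 1.5-fold higher number from compound 2 to compound 3 (0.18 log units; within the scatter). Nothing among the three therefore separates one amide substituent from another.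

Compound 4 `COc1ccc2c(=O)c(/C=C/C(=O)Nc3ccccc3OC)coc2c1` is not yet measured. It differs from compound 1 by methoxy in place of hydrogen on an aromatic carbon. Going by the values given here, the only measured step of the same kind, a 1.4-fold higher number from compound 1 to compound 3 (0.14 log units; within the scatter), stayed within the scatter, though it placed the group on a different carbon of the same ring. Compound 4 is therefore expected to show no step beyond the scatter, with a 1.1-fold higher number from compound 1 to compound 4 (0.02 log units; within the scatter) as the anticipated change. In this assay compound 4 is estimated at 550000 nM, within a range of 330000 nM to 900000 nM.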

Compound 4, half-maximal cytotoxic concentration: 1050000 nM
Compound 4: the middle estimate sits 1.9-fold (0.28 log units) below what was measured; the measured number lies above the stated range.
By their numbers in this assay, from the lowest: compounds 2, 1, 3 and 4 (each within the scatter of the next, the first and the last beyond it).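

In this assay, the change from phenyl to 2-methoxyphenyl, with methoxy ortho to a large group, gives (a 2.0-fold higher number from compound 1 to compound 4 (0.30 log units; within the scatter)) and stays inside the scatter, as does the comparison with the 4-methoxyphenyl amide (a 1.5-fold higher number from compound 3 to compound 4 (0.17 log units; within the scatter)), so neither step sets this position apart. Going by these compounds alone, only one new step passes the scatter, and modestly (a 2.2-fold higher number from compound 2 to compound 4 (0.34 log units; beyond the scatter)): this is the first separation among the compounds, but it replaces the whole 3-fluorobenzyl group and so does not isolate the methoxy group. No measurement available here explains these numbers.

Going by these compounds, whether an amine or a carboxylic acid at this same place would give a step beyond the scatter remains open. So does whether a longer chain, such as ethoxy, would behave as methoxy does here.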